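The source may hold more compounds than are shown below. What is called first, only, known or untested is meant among the compounds shown, and "the series" means these compounds.

Measured so far:
compound 1 `CCCCc1cn(C[C@H](O)[C@H]2OC(=O)C(OCc3ccccc3)=C2OCc2ccccc2)nn1` — 18100 nM
compound 2 `COc1ccccc1-c1cn(C/C=C2\OC(=O)C(OCc3ccccc3)=C2OCc2ccccc2)nn1` — > 100000 nM

In a functional assay on HeLa cells (Homo sapiens) for antiproliferative activity, read by MTT assay, with a stated time of 72 h (a higher number here means a weaker inhibitor, a lower number a stronger inhibitor), compound 1 gives 18100 nM. For the measured compounds named here, compound 2 `COc1ccccc1-c1cn(C/C=C2\OC(=O)C(OCc3ccccc3)=C2OCc2ccccc2)nn1` returns only a limit, > 100000 nM, so compound 1 holds the only true number here, with compound 2 sitting at the limit of > 100000 nM in this assay, at which 1 of the 2 values shown sits. Compound 3 `O=C1O[C@H]([C@@H](O)Cn2cc(CCCCl)nn2)C(OCc2ccccc2)=C1OCc1ccccc1` has yet to be tested. It differs from compound 1 by chloro in place of methyl on a saturated chain carbon, three bonds along the chain from an aromatic carbon. Going by the values given here, with no measured step of this kind to lean on, the change is expected to move this assay little, if at all, beyond the usual scatter. Compound 3 is therefore expected near 15000 nM, within 6000 nM to 45000 nM, a step of a 1.2-fold lower number from compound 1 to compound 3 (0.08 log units; within the scatter).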

Compound 3, half-maximal inhibitory concentration: 36700 nM
For compound 3 the middle estimate is 2.4-fold (0.39 log units) below the measured one; the measured number falls inside the stated range.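

For the compounds shown here, replacing butyl with 3-chloropropyl gives a 2.0-fold higher number from compound 1 to compound 3 (0.31 log units; beyond the scatter) in this assay, the first measured step at this position. The end of the chain therefore does respond to chloro in place of methyl, though only modestly, and compound 3 still returns a true number rather than a limit. Nothing among the data shown accounts for the direction of this step. As far as these compounds go, whether an amine, a carboxylic acid or a longer chain at this position would lower the number remains open. So does whether a different halogen, such as fluoro, would behave as chloro does.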